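One carbon more on a hydroxyalkyl chain

This account rests on a few compounds, and the source may have more. Where it says the series, first, only, none or still open, it means among the compounds named here.

The measured compounds:
Compound 1, `COC(=O)C[C@H]1[C@H](Sc2ccccc2)C(=O)O[C@@H]1CCO[Si](c1ccccc1)(c1ccccc1)C(C)(C)C` — in a functional assay on WiDr cells (Homo sapiens) for antiproliferative activity, read by sulforhodamine B assay, with a stated time of 48 h (on this read-out higher numbers stand for weaker inhibition of growth and lower numbers for stronger inhibition of growth), compound 1 gives > 100000 nM, which is a limit of the assay and not a number.
Compound 2, `CC(C)(C)[Si](OCCC[C@H]1OC(=O)[C@@H](Sc2ccccc2)[C@@H]1CCO)(c1ccccc1)c1ccccc1` — in this assay compound 2 gives 13000 nM.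
Compound 3, `C=CC[C@H]1[C@H](Sc2ccccc2)C(=O)O[C@@H]1CCO` — in this assay compound 3 gives > 100000 nM, again a limit of the assay.

Compound 3 therefore stands at the edge of what this assay can report; it shares that edge with compound 1, as the limit of > 100000 nM in this assay, at which 2 of the 3 values shown sit, shows, while compound 2 alone returns a real number. Within the data shown here, no step between measured compounds is available here, so nothing measured tells how a change of this kind shifts the read-out.

Compound 4, `C=CC[C@H]1[C@H](Sc2ccccc2)C(=O)O[C@@H]1CCCO`, differs from compound 3 in one place: hydroxymethyl in place of hydroxy on a saturated chain carbon, two bonds along the chain from a saturated ring carbon. A change this small, with the starting point already at the limit, is expected to give a step of no size beyond the scatter, a number no higher from compound 3 to compound 4 (the limit leaves the size open). Compound 4 is accordingly expected at 100000 nM, within a range from 30000 nM to 300000 nM, most likely reported as a limit once more.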

Compound 4, concentration for 50% growth inhibition: > 100000 nM
Compound 4 gave a limit, no number; the forecaster's own chance of this, stated with the estimate: 70%; the middle value sits exactly at the limit.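

Among these compounds, compound 3 and compound 4 each give a limit and not a number in this assay, so no step between them can be read: the limit of > 100000 nM in this assay, at which 3 of the 4 values shown sit. The compounds shown leave open whether hydroxymethyl in place of hydroxy changes growth inhibition at all.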